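Thiophen-2-yl in place of 4-(dimethylamino)phenyl

The source may hold more compounds than are shown below. What is called first, only, known or untested is meant among the compounds shown, and "the series" means these compounds.

In a functional assay, with a stated time of 10 min (on this read-out higher numbers stand for weaker inhibition and lower numbers for stronger inhibition), compound 1 (`CCOC(=O)c1cnn(-c2nc(-c3ccc(OC)cc3)c(C#N)c(=O)n2C)c1N`) gives 74 ug/mL and compound 2 (`CCOC(=O)c1cnn(-c2nc(-c3cccc(OC)c3OC)c(C#N)c(=O)n2C)c1N`) gives 67 ug/mL while compound 3 (`CCOC(=O)c1cnn(-c2nc(-c3ccc(N(C)C)cc3)c(C#N)c(=O)n2C)c1N`) gives 119 ug/mL on the same read-out. Compound 3 stands level with the other two, as a 1.6-fold higher number from compound 1 to compound 3 (0.21 log units; within the scatter) and a 1.8-fold higher number from compound 2 to compound 3 (0.25 log units; within the scatter) show, and a 1.1-fold lower number from compound 1 to compound 2 (0.04 log units; within the scatter) leaves those two level as well. Compound 4 (`CCOC(=O)c1cnn(-c2nc(-c3cccs3)c(C#N)c(=O)n2C)c1N`) carries thiophen-2-yl in place of 4-(dimethylamino)phenyl on an aromatic carbon. Among the measured compounds shown here, no measured step brings in a five-membered aromatic ring, so these three steps are the only guide. No step beyond the scatter is therefore expected in this assay here. The expected change is a 1.4-fold lower number from compound 3 to compound 4 (0.15 log units; within the scatter) and no more. For compound 4 the estimate is 85 ug/mL with an expected range from 42 ug/mL to 170 ug/mL in this test.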

Compound 4, half-maximal inhibitory concentration: 109 ug/mL
Beside the measured number, compound 4's estimate is 1.3-fold (0.11 log units) below it, within the range that was stated.
By their numbers in this assay, from the lowest: compounds 2, 1, 4 and 3 (each within the scatter of the next).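

In this assay, the aromatic carbon ortho to a cyano group accepts a five-membered aromatic ring with 1 hetero atom as well as the six-membered aromatic rings of carbon only, with no step beyond the scatter (a 1.1-fold lower number from compound 3 to compound 4 (0.04 log units; within the scatter)) and (a 1.6-fold higher number from compound 2 to compound 4 (0.21 log units; within the scatter)) and (a 1.5-fold higher number from compound 1 to compound 4 (0.17 log units; within the scatter)). Thiophen-2-yl, with 5 heavy atoms against the 9 of 4-(dimethylamino)phenyl, therefore stands level with all three earlier compounds. No available evidence explains this flat result. As far as these compounds go, whether a carboxylic acid, a primary amine or a longer alkyl chain at this position would give a step beyond the scatter remains open.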